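Adding a Methyl to the Urea Series: Expected Exposure

The compounds below may be only part of what the source reports. "The series", "measured", "known", "first", "only" and "open" are said of these compounds alone.

In an in vivo ADME assay on the whole organism (strain BALB/cAnNCrl) for pharmacokinetics, with Mus musculus as the target, at a dose of 10 mg/kg by the oral route (on this read-out higher numbers stand for higher exposure at the dose given and lower numbers for lower exposure), compound 2 `CC(C)(C)c1cc(NC(=O)Nc2ccc(Oc3ccnc4[nH]c(=O)[nH]c34)cc2F)n(-c2ccccc2)n1` gives 15000 nM. Compound 1 `Cc1ccc(-n2nc(C(C)(C)C)cc2NC(=O)Nc2ccc(Oc3ccnc4c3n(C)c(=O)n4C)cc2F)cc1` gives 8120 nM in this assay, and the two numbers sit within the usual scatter of each other, so neither stands apart. Compound 3 `Cc1ccc(-n2nc(C(C)(C)C)cc2NC(=O)Nc2ccc(Oc3ccnc4[nH]c(=O)[nH]c34)cc2F)cc1` differs from compound 2 by a single change: methyl in place of hydrogen on an aromatic carbon. Among the compounds with values here, no measured pair isolates this change, so the expectation rests on compound 2 alone. The step in this assay is expected to be small, in either direction or none beyond the scatter, giving a 1.3-fold lower number from compound 2 to compound 3 (0.10 log units; within the scatter). Compound 3 is therefore estimated at 12000 nM, with a range from 5000 nM to 28000 nM.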

Compound 3, maximal plasma concentration: 7430 nM
Estimate against measurement, compound 3: 1.6-fold (0.21 log units) above; low and high end bracket the measured number.
By their numbers in this assay, from the lowest: compounds 3, 1 and 2 (each within the scatter of the next, the first and the last beyond it).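

Within the data shown here, the change from phenyl to 4-methylphenyl gives a 2.0-fold lower number from compound 2 to compound 3 (0.31 log units; beyond the scatter) in this assay and is the first direct reading at this position, where a single added carbon is enough for a modest step. With the 4-methylphenyl kept, replacing the group on the oxygen gives a 1.1-fold lower number from compound 1 to compound 3 (0.04 log units; within the scatter) and so leaves compound 1 and compound 3 indistinguishable on this read-out. No measurement shown here explains the methyl step.

On these data alone, whether ethyl, methoxy or an amine at this position would behave like methyl remains open. Also open, as far as these compounds go, is whether the methyl step would hold on the core of compound 1.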